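This account rests on a few compounds, and the source may have more. Where it says the series, first, only, none or still open, it means among the compounds named here.

Measured in a functional assay on PC-3 cells (Homo sapiens) for inhibition, read by sulforhodamine B assay, with a stated time of 48 h; on this read-out lower numbers stand for stronger inhibition of growth and higher numbers for weaker inhibition of growth:
compound 1 `CCOC(=O)C1=C(C)NC(=O)NC1c1ccc(SC)cc1` gives 9.5 ug/mL;
compound 2 `CCCc1ccc(C2NC(=S)NC(C)=C2C(=O)OCC)cc1` gives 42.4 ug/mL;
compound 3 `CCOC(=O)C1=C(C)NC(=S)NC1c1ccc(SC)cc1` gives 23.6 ug/mL.

Compound 1 has the lowest of the three numbers; compound 3 stands nearest to it and compound 2 furthest, and both of those gaps lie beyond the scatter. How the core of compound 1 differs from the core of compound 3 is not broken down here. Compound 3 and compound 2 share a core and differ in one place, (propyl in place of methylsulfanyl on an aromatic carbon); the step is a 1.8-fold higher number from compound 3 to compound 2 (0.25 log units; within the scatter). Compound 4 `CCCc1ccc(C2NC(=O)NC(C)=C2C(=O)OCC)cc1` has not yet been measured in this assay. It stands to compound 1 as compound 2 stands to compound 3: propyl in place of methylsulfanyl on an aromatic carbon, the same change at the same place. The expectation for compound 4 rests on that single prior step, because a 1.8-fold higher number from compound 3 to compound 2 (0.25 log units; within the scatter) lay within the scatter. A step of similar size is expected for compound 4, a 1.8-fold higher number from compound 1 to compound 4 (0.25 log units; within the scatter). Accordingly compound 4 is estimated at 17 ug/mL in this assay, with a range from 8 ug/mL to 36 ug/mL.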

Compound 4, concentration for 50% growth inhibition: 25 ug/mL
Compound 4: the middle estimate sits 1.5-fold (0.17 log units) below what was measured; low and high end bracket the measured number.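

Placing propyl where methylsulfanyl stood, on an aromatic carbon para to a large group, gives a 2.6-fold higher number from compound 1 to compound 4 (0.42 log units; beyond the scatter) in this assay. Set beside the earlier step on the other core, the new step cannot be told apart from it, so the change carries across these two cores as far as this read-out can show: the same change on two cores in this assay, a 1.8-fold higher number (0.25 log units; within the scatter) from compound 3 to compound 2 and a 2.6-fold higher number (0.42 log units; beyond the scatter) from compound 1 to compound 4, 1.5-fold (0.17 log units) apart, within the scatter of two such steps This supports transfer between these two cores only; it does not fix a single size for the step, since the earlier step lies within the scatter and the new one beyond it, and two pairs set no rule for other cores in the series.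

The compounds shown leave open how other groups at this place would read, such as an amine, a carboxylic acid or a chain longer than propyl. They also leave open whether the same change would give a step of similar size on any further core, or in cells other than those of this assay.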